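The source may hold more compounds than are shown below. What is called first, only, known or untested is meant among the compounds shown, and "the series" means these compounds.

In a functional assay on MCF7 cells (Homo sapiens) for cytotoxicity, read by MTT assay, with a stated time of 48 h (a higher number here means a weaker inhibitor, a lower number a stronger inhibitor), compound 1 `CCc1ccc(NC(=S)N/N=C\c2ccnc3ccccc23)cc1` gives 820 nM, compound 2 `Fc1ccc(NC(=S)N/N=C\c2ccnc3ccccc23)cc1` gives 1100 nM and compound 3 `S=C(N/N=C\c1ccnc2ccccc12)Nc1ccc(Cl)cc1` gives 1070 nM. These three cannot be told apart, so compound 1 stands level with the other two. Compound 4 `Cc1ccc(NC(=S)N/N=C\c2ccnc3ccccc23)cc1` differs from compound 1 by one small edit, (hydrogen in place of methyl on a saturated chain carbon bound to an aromatic carbon), which turns ethyl into methyl, or 4-ethylphenyl into 4-methylphenyl. For the measured compounds named here, no measured step makes this exact change. The closest evidence comes from fluoro in place of ethyl, a 1.3-fold higher number from compound 1 to compound 2 (0.13 log units; within the scatter), and chloro in place of ethyl, a 1.3-fold higher number from compound 1 to compound 3 (0.12 log units; within the scatter). Both stayed within the scatter, so no step beyond the scatter is expected in this assay. The estimated value for compound 4 is 950 nM, within a range of 500 nM to 1800 nM. That expectation amounts to a 1.2-fold higher number from compound 1 to compound 4 (0.06 log units; within the scatter).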

Compound 4, half-maximal inhibitory concentration: 980 nM
Compound 4: middle estimate off by 1.0-fold (0.01 log units), on the low side; low and high end bracket the measured number.
By their numbers in this assay, from the lowest: compounds 1, 4, 3 and 2 (each within the scatter of the next).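

Shortening 4-ethylphenyl to 4-methylphenyl gives a 1.2-fold higher number from compound 1 to compound 4 (0.08 log units; within the scatter) in this assay, so trimming this chain by one carbon leaves the cell result unchanged. Methyl also stands level with both halogens on this aromatic carbon, with a 1.1-fold lower number from compound 3 to compound 4 (0.04 log units; within the scatter) and a 1.1-fold lower number from compound 2 to compound 4 (0.05 log units; within the scatter), so ethyl, methyl, fluoro and chloro cannot be told apart here. No accompanying measurement offers an explanation for this flat result. Still open, on these data alone, is whether a different kind of group at this place, such as an amine, a carboxylic acid or a longer chain, would move the number beyond the scatter.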